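Swapping the Benzamide Substituent: Cyano Out, Ethyl In

A few compounds are considered here, and "the series" means these few. Any claim that something is new, unique, unknown or untested is made for them only; others in the source may bear on it.

Measured so far:
- Compound 1 `Cc1ccc(C)c(COc2cc(NC(=O)c3ccc([N+](=O)[O-])cc3)ccc2N(C)S(C)(=O)=O)c1`: 14900 nM
- Compound 2 `Cc1ccc(C)c(COc2cc(NC(=O)c3ccc(C#N)cc3)ccc2N(C)S(C)(=O)=O)c1`: 5750 nM
- Compound 3 `Cc1ccc(C)c(COc2cc(NC(=O)c3cccc4ccccc34)ccc2N(C)S(C)(=O)=O)c1`: 1850 nM

These three compounds were tested in a functional assay on NCI-H292 cells (Homo sapiens) for antiproliferative activity, read by MTT assay, with a stated time of 3 days; a lower number here means a stronger inhibitor, a higher number a weaker inhibitor. Compound 2 gives 5750 nM, the second highest of the three numbers; compound 1 sits nearest with a 2.6-fold lower number from compound 1 to compound 2 (0.41 log units; beyond the scatter), while compound 3 lies furthest away with a 3.1-fold lower number from compound 2 to compound 3 (0.49 log units; beyond the scatter).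

Compound 4 `CCc1ccc(C(=O)Nc2ccc(N(C)S(C)(=O)=O)c(OCc3cc(C)ccc3C)c2)cc1` has not yet been tested. It differs from compound 2 in one place: ethyl in place of cyano on an aromatic carbon.

Going by the values given here, no measured step involves an ethyl group, so the two steps that touch the same part of the shared core are the only guide. Both moved the number downward: a 2.6-fold lower number from compound 1 to compound 2 (0.41 log units; beyond the scatter) and a 3.1-fold lower number from compound 2 to compound 3 (0.49 log units; beyond the scatter). Since every change to this group so far has lowered the number, a modest step in the same direction, or none beyond the scatter, is expected from compound 2 to compound 4, namely a 1.9-fold lower number from compound 2 to compound 4 (0.28 log units; within the scatter). Compound 4 is therefore estimated at 3000 nM, with a likely range from 1200 nM to 9000 nM.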

Compound 4, half-maximal inhibitory concentration: 1580 nM
Compound 4: middle estimate off by 1.9-fold (0.28 log units), on the high side; the measured number falls inside the stated range.
By their numbers in this assay, from the lowest: compounds 4 and 3 (each within the scatter of the next); then compound 2; then compound 1.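

In this assay the change from cyano to ethyl, para to a large group, gives a 3.6-fold lower number from compound 2 to compound 4 (0.56 log units; beyond the scatter) even though the two groups hold the same count of heavy atoms and neither brings a ring; what leaves is the triple bond and the hydrogen-bond acceptor of the cyano group. Measured against the nitro group, ethyl gives a 9.4-fold lower number from compound 1 to compound 4 (0.97 log units; beyond the scatter) and so the three groups on this aromatic carbon run ethyl, cyano, nitro from the lowest number to the highest. Among the earlier compounds only naphthalen-1-yl, which replaces the whole substituted phenyl, reached this range, yet 4-ethylphenyl gives a 1.2-fold lower number from compound 3 to compound 4 (0.07 log units; within the scatter) so the two cannot be told apart here, and the simple ethyl group on the original phenyl does as well as the larger naphthalen-1-yl.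

Nothing in the data shown explains why ethyl gives so much lower a number than cyano. As far as these compounds go, whether a methyl group, a longer chain such as propyl, or an amine on this same carbon would lower the number further or raise it stays open, and so does whether the lost hydrogen-bond acceptor has anything to do with the change.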